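Sulfonyl for Benzyl: Cytotoxicity Expectations in Cultured Cells

The source may report more compounds than this note shows. Statements on the series, on what has been measured and on what is new or still open speak of the compounds shown alone.

Four compounds are compared here. Compound 1 `Cc1cc(C)cc(Cn2c(SCC(=O)Nc3ccccc3Cl)nc3ccc(Cl)cc32)c1` and compound 2 `Cc1cc(C)cc(S(=O)(=O)n2c(SCC(=O)Nc3ccccc3Cl)nc3ccc(Cl)cc32)c1` share one core; compound 3 `Cc1cc(C)cc(Cn2c(SCC(=O)Nc3ccccc3[N+](=O)[O-])nc3ccccc32)c1` and compound 4 `Cc1cc(C)cc(S(=O)(=O)n2c(SCC(=O)Nc3ccccc3[N+](=O)[O-])nc3ccccc32)c1` share another, and the difference between the two cores is not broken down here.

In an ADME assay on MT4 cells (Homo sapiens) for cytotoxicity (on this read-out higher numbers stand for lower toxicity in this test and lower numbers for higher toxicity in this test), compound 1 gives 141000 nM. Compound 2 differs from compound 1 by (3,5-dimethylphenyl)sulfonyl in place of 3,5-dimethylbenzyl on an aromatic nitrogen, and in this assay compound 2 gives 99300 nM, so that a 1.4-fold lower number from compound 1 to compound 2 (0.15 log units; within the scatter). In this assay compound 3 gives 194000 nM; its value, that of compound 1 and that of compound 2 all sit within the usual scatter of one another, so none of the three is set apart on this read-out.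

Compound 4 differs from compound 3 by (3,5-dimethylphenyl)sulfonyl in place of 3,5-dimethylbenzyl on an aromatic nitrogen. The place is described in the same words as for the pair of compound 1 and compound 2, so this is the same change, made a second time on a different core. For the measured compounds named here, the single measured instance of it is the only basis for an expectation. Because a 1.4-fold lower number from compound 1 to compound 2 (0.15 log units; within the scatter), the step of a 1.4-fold lower number from compound 3 to compound 4 (0.14 log units; within the scatter) is expected to be small as well. Compound 4 is accordingly estimated to give about 140000 nM in this assay, with a plausible range from 70000 nM to 280000 nM, pending the actual measurement.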

Compound 4, half-maximal cytotoxic concentration: >= 26000 nM
Compound 4: no number, only a limit (the forecaster's own chance of this, stated with the estimate: 15%); the middle value does not contradict the limit.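

Compound 4 gives no number in this assay, so the step from compound 3 to compound 4 cannot be read, because its result is only a limit: the limit of >= 26000 nM in this assay, at which 1 of the 4 values shown sits.

The compounds shown leave open whether (3,5-dimethylphenyl)sulfonyl in place of 3,5-dimethylbenzyl changes the read-out on the core of compound 3 as little as it does on the core of compound 1.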